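Cyclic Urea to Tetrazole: Expected Stability of Compound 4

The source may hold more compounds than are shown below. What is called first, only, known or untested is meant among the compounds shown, and "the series" means these compounds.

Compound 1 `CC(C)NC(=O)CC(c1ccc(-c2ccc3cccc(F)c3c2)[nH]c1=O)C(C)C`: in an ADME assay on microsomes from liver (Mus musculus) for metabolic stability (a higher number here means that the compound lasts longer, a lower number that the compound disappears faster), compound 1 reaches only a limit of the assay, < 0.0667 h.
Compound 2 `CC(C)C(c1ccc(-c2ccc3cccc(F)c3c2)[nH]c1=O)N1CCCCC1=O`: in this assay compound 2 gives 0.0967 h.
Compound 3 `CC(C)C(c1ccc(-c2ccc3cccc(F)c3c2)[nH]c1=O)N1CCNC1=O`: in this assay compound 3 gives 0.682 h.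

Compound 3 stands highest of the two numbers, with a 7.1-fold higher number from compound 2 to compound 3 (0.85 log units; beyond the scatter) beyond the scatter. Compound 1 sits at a limit, (the limit of < 0.0667 h in this assay, at which 1 of the 3 values shown sits). Compound 4 `CC(C)C(Cc1nnn[nH]1)c1ccc(-c2ccc3cccc(F)c3c2)[nH]c1=O` carries (1H-tetrazol-5-yl)methyl in place of 2-oxoimidazolidin-1-yl on a saturated chain carbon bound to an aromatic carbon and a saturated chain carbon. Within the data shown here, no measured step makes this exchange; the nearest, a 7.1-fold higher number from compound 2 to compound 3 (0.85 log units; beyond the scatter) and an at least 10-fold higher number from compound 1 to compound 3 (1.00 log units; beyond the scatter), show that changing the group at this position can shift the half-life beyond the scatter, and compound 3 holds the only long value. A modest drop is therefore expected, a 1.9-fold lower number from compound 3 to compound 4 (0.29 log units; within the scatter). Compound 4 is estimated at 0.35 h, between 0.1 h and 1.2 h.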

Compound 4, half-life: 0.853 h
Compound 4: the middle estimate sits 2.4-fold (0.39 log units) below what was measured; low and high end bracket the measured number.
By their numbers in this assay, from the lowest: compound 2; then compounds 3 and 4 (each within the scatter of the next). At a limit, below all of these: compound 1.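

In this assay, the (1H-tetrazol-5-yl)methyl group cannot be told apart from the 2-oxoimidazolidin-1-yl group at this place, with a 1.3-fold higher number from compound 3 to compound 4 (0.10 log units; within the scatter), so a long half-life here is no longer tied to that one group. Compound 4 also stands clear of the 2-oxopiperidin-1-yl compound, with an 8.8-fold higher number from compound 2 to compound 4 (0.95 log units; beyond the scatter). Against compound 1, which sits only at a limit of the assay, the step is a floor, an at least 12-fold higher number from compound 1 to compound 4 (1.10 log units; beyond the scatter): the limit of < 0.0667 h in this assay, at which 1 of the 4 values shown sits.

Going by these compounds, whether a carboxylic acid, an amine or a longer chain at this place would give a comparable half-life remains open.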